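Ester Variation on a Shared Terpenoid Core

The source may report more compounds than this note shows. Statements on the series, on what has been measured and on what is new or still open speak of the compounds shown alone.

For the measured compounds named here, compound 3 `CC1=CC[C@H](C(C)C)c2cc(C)c(OC(=O)c3ccc(Cl)cc3)cc21` is the only member of this small set to return a numerical value in a functional assay on K562 cells (Homo sapiens) for antiproliferative activity, read by sulforhodamine B assay, with a stated time of 48 h, tested at 50 uM (a higher number here means more inhibition at the concentration tested (going by the name of the read-out), a lower number less inhibition), where compound 3 gives 58.9%. Compound 1 `COc1cccc(C(=O)Oc2cc3c(cc2C)[C@@H](C(C)C)CC=C3C)c1` gives "not active" (no number reported) in this assay, and compound 2 `CC1=CC[C@H](C(C)C)c2cc(C)c(OC(=O)c3ccccc3)cc21` likewise gives "not active" (no number reported). The next compound, compound 4 `CC1=CC[C@H](C(C)C)c2cc(C)c(OC(=O)c3cccc(C)c3)cc21`, carries 3-methylphenyl in place of 4-chlorophenyl on a carbonyl carbon. Going by the values given here, no measured step between related compounds exists to anchor the size of this change, so the expectation rests on compound 2 alone: because compound 2 gives "not active" (no number reported), a downward step is anticipated. The step from compound 3 to compound 4 is estimated at a number 30.9 percentage points lower from compound 3 to compound 4 (beyond the scatter), beyond the usual scatter. Compound 4 is therefore expected to give about 28%, within a range from 5% to 55%.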

Compound 4, a percentage reported as inhibition, at one concentration (the size of the read-out at that concentration, not a potency): "not active" (no number reported)
Nothing numeric was reported for compound 4; no gap can be computed for the estimate.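

For the compounds shown here, compound 4 gives "not active" (no number reported) in this assay and offers no number, so no step from compound 3 to it can be read. Nothing shown bears on this result. The compounds shown leave open whether the 4-chlorophenyl group alone sets compound 3 apart from the other esters.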